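The source may report more compounds than this note shows. Statements on the series, on what has been measured and on what is new or still open speak of the compounds shown alone.

Compound 1 `CC(C)(C)Sc1c(CC(C)(C)C(=O)O)n(Cc2ccc(Cl)cc2)c2ccc(OCc3cc4ccccc4cn3)cc12`: 3 nM in a functional assay for inhibition, with Homo sapiens as the target; on this read-out lower numbers stand for stronger inhibition and higher numbers for weaker inhibition. Compound 2 `CC(C)(C)Sc1c(CC(C)(C)C(=O)O)n(Cc2ccc(Cl)cc2)c2ccc(OCc3ccc4cnccc4n3)cc12`: 3 nM. Compound 3 `Cc1nc2ccc(COc3ccc4c(c3)c(SC(C)(C)C)c(CC(C)(C)C(=O)O)n4Cc3ccc(Cl)cc3)cc2s1`: 6 nM.

Compound 3 has the highest of these three numbers, though its steps to the others, a 2.0-fold higher number from compound 1 to compound 3 (0.30 log units; within the scatter) and a 2.0-fold higher number from compound 2 to compound 3 (0.30 log units; within the scatter), both stay within the scatter, as does no change at the digits printed from compound 1 to compound 2 (within the scatter). Compound 4 `CC(C)(C)Sc1c(CC(C)(C)C(=O)O)n(Cc2ccc(Cl)cc2)c2ccc(OCc3ccncc3)cc12` differs from compound 3 in one place: pyridin-4-yl in place of 2-methyl-1,3-benzothiazol-6-yl on a saturated chain carbon bound to an oxygen on an aromatic ring. For the measured compounds named here, every measured step exchanges one group of 10 heavy atoms for another of the same count; none removes a ring, so no measured step directly matches this change. The group entering is smaller by four heavy atoms, and the estimate for compound 4 therefore allows a step beyond the scatter, a 2.5-fold higher number from compound 3 to compound 4 (0.40 log units; beyond the scatter), towards a higher number. Compound 4 is expected to give 15 nM, between 4 nM and 60 nM.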

Compound 4, half-maximal inhibitory concentration: 6 nM
Estimate against measurement, compound 4: 2.5-fold (0.40 log units) above; the measured number falls inside the stated range.
By their numbers in this assay, from the lowest: compounds 1, 2, 3 and 4 (each within the scatter of the next).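

In this assay the group on the saturated chain carbon bound to an oxygen on an aromatic ring can shrink to a single ring with little effect: the read-out shows no change at the digits printed from compound 3 to compound 4 (within the scatter) and a 2.0-fold higher number from compound 2 to compound 4 (0.30 log units; within the scatter) and a 2.0-fold higher number from compound 1 to compound 4 (0.30 log units; within the scatter) in turn. The earlier steps shown here only exchanged groups of equal size, so they could not show that a whole ring can go. Nothing available explains this result.

As far as these compounds go, whether any ring is needed here remains open, as a plain amine or a carboxylic acid on that carbon would test.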